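A few compounds are considered here, and "the series" means these few. Any claim that something is new, unique, unknown or untested is made for them only; others in the source may bear on it.

In a functional assay on A549 cells (Homo sapiens) for cytotoxicity (a higher number here means a weaker inhibitor, a lower number a stronger inhibitor), two compounds that share one core and differ only in the group on an aromatic nitrogen have been measured. Compound 1 `C[C@@H]1O[C@@H](n2c3ccccc3c3c4c(c5c6ccccc6ccc5c32)C(=O)NC4=O)[C@H](O)[C@H](O)[C@H]1O` gives 2800 nM, and compound 2 `O=C1NC(=O)c2c1c1c3ccccc3ccc1c1c2c2ccccc2n1[C@H]1OC[C@@H](O)[C@@H](O)[C@H]1O` gives 2000 nM. Among the measured compounds shown here, compound 2 therefore stands level with compound 1, as the only measured step, a 1.4-fold lower number from compound 1 to compound 2 (0.15 log units; within the scatter), does not leave the scatter of repeated measurements.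

Compound 3 `O=C1NC(=O)c2c1c1c3ccccc3ccc1c1c2c2ccccc2n1[C@@H]1O[C@H](CO)[C@@H](O)[C@H](O)[C@H]1O` has not yet been measured. It changes the group at the same place: a group of 11 heavy atoms (6 carbon, 5 oxygen; one six-membered non-aromatic ring with 1 hetero atom) in place of a group of 9 heavy atoms (5 carbon, 4 oxygen; one six-membered non-aromatic ring with 1 hetero atom), on an aromatic nitrogen. The entering group is 3,4,5-trihydroxy-6-(hydroxymethyl)oxan-2-yl.

For the measured compounds named here, the one measured step bears on this change, since it also exchanges one six-membered non-aromatic ring with 1 hetero atom for another on an aromatic nitrogen. Going by the values given here, it is only a single step, however, and two compounds give thin support for any trend. No step beyond the scatter is therefore expected in this assay, and no clear direction can be assigned.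

The estimated 1.2-fold higher number from compound 2 to compound 3 (0.06 log units; within the scatter) stays within the scatter. For compound 3 the expected value is 2300 nM, with an estimated range of 800 nM to 7000 nM.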

Compound 3, half-maximal inhibitory concentration: 2800 nM
Beside the measured number, compound 3's estimate is 1.2-fold (0.09 log units) below it, within the range that was stated.
By their numbers in this assay, from the lowest: compounds 2, 1 and 3 (each within the scatter of the next).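

In this assay, the larger group 3,4,5-trihydroxy-6-(hydroxymethyl)oxan-2-yl on the aromatic nitrogen gives a 1.4-fold higher number from compound 2 to compound 3 (0.15 log units; within the scatter), so this second exchange of one six-membered non-aromatic ring for another also stays within the scatter, and the three compounds stand level. The comparison with the 3,4,5-trihydroxy-6-methyloxan-2-yl group adds a direct reading of hydroxymethyl in place of methyl on that ring, which gives no change at the digits printed from compound 1 to compound 3 (within the scatter), so this position tolerates that exchange and the change in group size seen here without a measurable shift in this assay. No supporting evidence bears on this result, and the numbers alone offer no explanation for it.

All three groups are hydroxylated six-membered rings with 1 hetero atom, so the compounds shown say nothing about how a markedly different group would read at this aromatic nitrogen. From the compounds shown here alone, it remains open whether an amine or a carboxylic acid on the ring, or a plain alkyl chain in place of the ring, would move the number in this assay beyond the scatter.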